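Fluoro for nitro at the limit of the assay

The source may hold more compounds than are shown below. What is called first, only, known or untested is meant among the compounds shown, and "the series" means these compounds.

Of the compounds shown here, three sharing one core have been measured in a functional assay on the whole organism (Tail) for activation, with Mus musculus as the target, with a stated time of 1 min; a lower number here means that less compound is needed, a higher number that more compound is needed for the effect. Compound 1 `O=C1NC(=O)N(/N=C/c2ccc(-c3ccc(Cl)cc3)o2)C1O` reads > 1000 mg/kg, which is a limit of the assay and not a number. Compound 2 `N#Cc1ccc(-c2ccc(/C=N/N3C(=O)NC(=O)C3O)o2)cc1` gives 743 mg/kg. Compound 3 `O=C1NC(=O)N(/N=C/c2ccc(-c3ccc([N+](=O)[O-])cc3)o2)C1O` reads > 1000 mg/kg, again only a limit, so it has no exact value to start from.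

Compound 4 `O=C1NC(=O)N(/N=C/c2ccc(-c3ccc(F)cc3)o2)C1O` carries fluoro in place of nitro on an aromatic carbon, para to a large group: fluoro in place of nitro on an aromatic carbon. Among the measured compounds shown here, no measured step makes this exact exchange, but three change the same substituent. Cyano in place of chloro gives an at least 1.3-fold lower number from compound 1 to compound 2 (0.12 log units; that floor lies within the scatter). Nitro in place of cyano gives an at least 1.3-fold higher number from compound 2 to compound 3 (0.12 log units; that floor lies within the scatter). Nitro in place of chloro gives a step that the two limits leave unreadable from compound 1 to compound 3.

Neither readable floor goes beyond the scatter, and the series sits largely at the limit of > 1000 mg/kg in this assay, at which 2 of the 3 values shown sit. No step beyond the scatter is therefore expected in this assay, and another limit is the likeliest report. The expected change is a number no higher from compound 3 to compound 4 (the limit leaves the size open). For compound 4 the estimate is 1000 mg/kg, with an expected range from 500 mg/kg to 2000 mg/kg.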

Compound 4, dose for half-maximal effect: > 1000 mg/kg
Compound 4: a limit, no number; the forecaster's own chance of this, stated with the estimate: 65%; the middle value lies on the limit itself.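

In this assay, compound 4 gives > 1000 mg/kg, which is a limit of the assay and not a number, so fluoro at this place, para to a large group, yields no exact reading, as chloro and nitro did not. Fluoro in place of cyano gives an at least 1.3-fold higher number from compound 2 to compound 4 (0.12 log units; that floor lies within the scatter), while the steps to compound 4 from the two other limits cannot be read. Among the four substituents, cyano alone has given an exact value, and the series now rests even more on the ceiling of the assay: the limit of > 1000 mg/kg in this assay, at which 3 of the 4 values shown sit.

Going by these compounds, how far compound 1, compound 3 and compound 4 lie past that limit remains open, so no order among chloro, nitro and fluoro can be given. Also open, on these data alone, is whether an amine or a carboxylic acid at this place would give a reading inside the range of the assay.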